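A few compounds are considered here, and "the series" means these few. Any claim that something is new, unique, unknown or untested is made for them only; others in the source may bear on it.

Measured compounds:
Compound 1 `CCCCCCCCCCCCCCCCCCOCC(COP(=O)(O)O[C@H](C)C[N+](C)(C)C)OC`. In an ADME assay (Homo sapiens) for cytotoxicity, with a stated time of 24 h (a lower number here means a stronger inhibitor, a higher number a weaker inhibitor), compound 1 gives > 100 ug/mL, which is a limit of the assay and not a number.
Compound 2 `CCCCCCCCCCCCCCCCCCOCC(COP(=O)(O)O[C@@H](C)C[N+](C)(C)C)OC`. In this assay compound 2 gives > 100 ug/mL, again a limit of the assay rather than a number.

Compound 2 therefore stands only at a limit on the numbers shown, and the single further value, that of compound 1, is a limit as well (the limit of > 100 ug/mL in this assay, at which 2 of the 2 values shown sit). Within the data shown here, the one measured step, a step that the two limits leave unreadable from compound 1 to compound 2, is a stereochemical change whose size the two limits leave unreadable (the fact that one of compounds 1 and 2 is drawn with a defined configuration and the other without, at the place where they differ).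

Compound 3 `CCCCCCCCCCCCCCCCCCOCC(COP(=O)(O)OC[C@@H](C)[N+](C)(C)C)OC` is the next target. Its change from compound 2 is a group of 7 heavy atoms (6 carbon, 1 nitrogen; no ring) in place of a group of 7 heavy atoms (6 carbon, 1 nitrogen; no ring), on an oxygen. Among the measured compounds shown here, no measured step covers an exchange of this kind at the oxygen bound to phosphorus; the only step recorded is the unreadable one between compound 1 and compound 2. Both measured values sitting at the limit give no reason to expect compound 3 to move off it, so the step that the limit leaves unreadable from compound 2 to compound 3 is expected to be none beyond the scatter. Compound 3 is estimated at 150 ug/mL in this assay, with a range from 60 ug/mL to 400 ug/mL, and most likely the assay again reports only a limit.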

Compound 3, concentration for 50% inhibition: > 100 ug/mL
Compound 3 ended at the assay's limit; the forecaster's own chance of this, stated with the estimate: 80%; the middle value does not contradict the limit.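

No step between compound 1, compound 2 and compound 3 can be read in this assay, because all three stand at a limit of the assay and not at a number: the limit of > 100 ug/mL in this assay, at which 3 of the 3 values shown sit.

As far as these compounds go, what stays open is the actual level of each compound in this assay, and whether the change of configuration or the exchange of groups on the oxygen shifts it at all.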